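This account rests on a few compounds, and the source may have more. Where it says the series, first, only, none or still open, it means among the compounds named here.

Of the compounds shown here, three have so far been tested in an assay for inhibition of steroid 17-alpha-hydroxylase/17,20 lyase (Homo sapiens), tested at 2 uM (on this read-out lower numbers stand for a weaker effect and higher numbers for a stronger effect at the one concentration tested), and a fourth awaits measurement. Compound 1 `COc1ccc2cc(-c3ccc(F)cc3)ccc2c1-c1cccnc1` gives 7% in this assay. Compound 2 `Oc1ccc2cc(-c3ccc(F)cc3)ccc2c1-c1cccnc1` carries the change hydrogen in place of methyl on an oxygen on an aromatic ring relative to compound 1; in this assay compound 2 gives 0%, so the step of a number 7 percentage points lower from compound 1 to compound 2 (within the scatter) is small. Compound 3 `COc1ccc2cc(-c3cccc(-c4cccnc4)c3)ccc2c1` has a different core from compound 1, and the difference between the two cores is not broken down here; in this assay compound 3 gives 4%, a number within the scatter of both compound 1 and compound 2.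

Compound 4 `Oc1ccc2cc(-c3cccc(-c4cccnc4)c3)ccc2c1` has not yet been measured. It differs from compound 3 by hydrogen in place of methyl on an oxygen on an aromatic ring, which is the same change that turns compound 1 into compound 2, made at the same kind of place on the other core. Since that change produced only the small step of a number 7 percentage points lower from compound 1 to compound 2 (within the scatter) from a low starting number, the step from compound 3 to compound 4 is expected to be about a number 3 percentage points lower from compound 3 to compound 4 (within the scatter), again within the scatter. Compound 4 is therefore estimated to give about 1% in this assay, most likely between 0% and 8%.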

Compound 4, a percentage reported as inhibition, at one concentration (the size of the read-out at that concentration, not a potency): 8%
Compound 4: the middle estimate sits 7 percentage points below what was measured; the range from low to high includes it.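

In this assay, the change from methoxy to hydroxy on the second core gives a number 4 percentage points higher from compound 3 to compound 4 (within the scatter) and so stays inside the usual scatter, as it did on the first core. Set side by side, the two steps do not differ: the same change on two cores in this assay, a number 7 percentage points lower (within the scatter) from compound 1 to compound 2 and a number 4 percentage points higher (within the scatter) from compound 3 to compound 4, 11 percentage points apart, within the scatter of two such steps. This shows that on these two cores the change leaves the read-out within the scatter, but all four numbers sit low on the scale, so it does not show that the change would carry over in the same way on a core with a clearly stronger effect, and steps this small give no reliable direction.

The compounds shown leave open whether an amine, a carboxylic acid or a longer chain such as ethoxy in place of the methoxy or hydroxy would give a clearly different number. With a single concentration in the read-out, they also leave open how these compounds would compare at higher concentrations.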